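This account rests on a few compounds, and the source may have more. Where it says the series, first, only, none or still open, it means among the compounds named here.

Compound 2 `CCOC(=O)C1=C(Nc2ccccc2)S/C(=C\c2cc[nH]c2)C1=O` sits at the limit of a functional assay on A549 cells (Homo sapiens) for inhibition, read by MTT assay, with a stated time of 72 h, tested at 10 uM; a lower number here means less inhibition, a higher number more inhibition at the concentration tested (going by the name of the read-out): its reading of < 10% marks only that limit, not a number. For the measured compounds named here, the single measured step, a number at least 20.7 percentage points lower from compound 1 to compound 2 (beyond the scatter), shows how strongly the group on this chain carbon can move the result; compound 1 `CCOC(=O)C1=C(Nc2ccccc2)S/C(=C\c2ccc(O)c(O)c2)C1=O` itself gives 30.7%. Compound 3 `CCOC(=O)C1=C(Nc2ccccc2)S/C(=C\c2cc3cccnc3[nH]2)C1=O` differs from compound 2 by a group of 9 heavy atoms (7 carbon, 2 nitrogen; one five-membered aromatic ring with 1 hetero atom, one six-membered aromatic ring with 1 hetero atom) in place of a group of 5 heavy atoms (4 carbon, 1 nitrogen; one five-membered aromatic ring with 1 hetero atom), on a double-bonded chain carbon bound to a double-bonded ring carbon. Going by the values given here, no measured step bears directly on this change, so only a guarded rise is expected, a number at least 5 percentage points higher from compound 2 to compound 3 (that floor lies within the scatter). Compound 3 is therefore estimated at 15%, with a range from 0% to 40%.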

Compound 3, a percentage reported as inhibition, at one concentration (the size of the read-out at that concentration, not a potency): 16.7%
Estimate against measurement, compound 3: 1.7 percentage points below; the measured number falls inside the stated range.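

Compound 2 gives only a limit in this assay: the limit of < 10% in this assay, at which 1 of the 3 values shown sits. From the compounds shown here alone, putting the larger group of compound 3 on this chain carbon gives a number at least 6.7 percentage points higher from compound 2 to compound 3 (that floor lies within the scatter), so a real rise is not established and its true size stays unknown. The same group gives a number 14 percentage points lower from compound 1 to compound 3 (beyond the scatter), so neither replacement for the 3,4-dihydroxyphenyl group shown here matches compound 1.

The compounds shown leave open whether a phenyl group carrying a single hydroxyl would hold the reading of compound 1. They also leave open what an amine or a carboxylic acid on this chain carbon would do.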